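Adding a bromoacetamide to the triazole chalcone

The source may hold more compounds than are shown below. What is called first, only, known or untested is meant among the compounds shown, and "the series" means these compounds.

Of the compounds shown here, two have been tested in a functional assay on HeLa cells (Homo sapiens) for inhibition, read by MTT assay; on this read-out lower numbers stand for stronger inhibition and higher numbers for weaker inhibition. Compound 2 `Nc1ccc(C(=O)/C=C/c2cn(Cc3ccc(Br)cc3)nn2)cc1` gives 16400 nM, the higher of the two numbers, while compound 1 `CCCCCCCCCCn1cc(/C=C/C(=O)c2ccc(NC(=O)CBr)cc2)nn1` gives 7410 nM, a gap beyond the usual scatter. Compound 3 `O=C(CBr)Nc1ccc(C(=O)/C=C/c2cn(Cc3ccc(Br)cc3)nn2)cc1` arises from compound 2 by one change: (bromomethyl)carbonyl in place of hydrogen on a nitrogen on an aromatic ring. For the measured compounds named here, no pair of measured compounds differs in only one place, so no measured step guides this change. The number for compound 3 is expected to fall, with an estimated step of a 2.3-fold lower number from compound 2 to compound 3 (0.37 log units; beyond the scatter). This expectation rests on compound 1, which carries the same group and gives 7410 nM. For compound 3 in this assay the estimate is 7000 nM, within 2500 nM to 20000 nM.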

Compound 3, half-maximal inhibitory concentration: 7950 nM
Compound 3: the middle estimate sits 1.1-fold (0.06 log units) below what was measured; low and high end bracket the measured number.
By their numbers in this assay, from the lowest: compounds 1 and 3 (each within the scatter of the next); then compound 2.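

In this assay, (bromomethyl)carbonyl in place of hydrogen on the aromatic amine nitrogen gives a 2.1-fold lower number from compound 2 to compound 3 (0.31 log units; beyond the scatter), a modest but real strengthening of inhibition. With that group present, 4-bromophenyl in place of nonyl gives a 1.1-fold higher number from compound 1 to compound 3 (0.03 log units; within the scatter), so this exchange shows no clear effect. Nothing measured here explains either step.

From the compounds shown here alone, whether the bromine in the new group matters remains open, as an acetyl or chloroacetyl group on the same nitrogen could show. Going by these compounds, how the amine-bearing compound 2 would respond to nonyl in place of 4-bromophenyl also remains open.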